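The compounds below may be only part of what the source reports. "The series", "measured", "known", "first", "only" and "open" are said of these compounds alone.

Measured compounds:
- compound 1, `O=C(O)Cc1sc(CSc2ccccc2)nc1-c1ccc(Cl)cc1`: in an in vitro assay on HEK385-7 cells for displacement of a labelled ligand from prostaglandin D2 receptor 2 (Homo sapiens) (on this read-out higher numbers stand for weaker inhibition and lower numbers for stronger inhibition), compound 1 gives 250 nM
- compound 2, `NS(=O)(=O)c1ccc(-c2nc(C(c3ccc(F)cc3)c3ccc(F)cc3)sc2CC(=O)O)cc1`: in this assay compound 2 gives 1500 nM

Of these two numbers, compound 2 has the higher one, and the gap to compound 1 is beyond the usual scatter, so compound 2 is the weaker of the two in this assay. Compound 3, `O=C(O)Cc1sc(C(c2ccc(F)cc2)c2ccc(F)cc2)nc1-c1cc(F)nc(F)c1`, has not been measured yet. It differs from compound 2 in one place: 2,6-difluoropyridin-4-yl in place of 4-sulfamoylphenyl on an aromatic carbon. The rest of the shared core, including the carboxymethyl group and the large group on the other side of the five-membered ring, stays as it is in compound 2. Among the compounds with values here, no measured pair shows this particular change, so any expectation rests on the two numbers above. Since compound 1 reaches 250 nM with a different group at the same position, compound 3 is expected to land somewhere between the two measured values, and the expected step of a 2.1-fold lower number from compound 2 to compound 3 (0.33 log units; beyond the scatter) points toward a lower number, of a size near the edge of the scatter. Compound 3 is estimated at 700 nM, with a range from 150 nM to 3000 nM.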

Compound 3, half-maximal inhibitory concentration: 5.4 nM
The estimate for compound 3 lay 130-fold (2.11 log units) above the measured number; measured number outside the range, below it.
By their numbers in this assay, from the lowest: compound 3; then compound 1; then compound 2.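

In this assay, putting 2,6-difluoropyridin-4-yl in place of 4-sulfamoylphenyl gives a 280-fold lower number from compound 2 to compound 3 (2.44 log units; beyond the scatter) and makes compound 3 the strongest of the three, so this aromatic carbon of the five-membered ring can have a very large effect on the read-out. The swap changes several things at once: a carbon-only ring becomes a ring with a hetero atom, two fluorines enter, and the sulfamoyl group with its hydrogen-bond donor leaves. No measurement shown here explains the size of this step.

The compounds shown leave open which of these changes carries the step, and a plain pyridin-4-yl or a plain phenyl at this carbon would help separate them. As far as these compounds go, it also remains open whether 2,6-difluoropyridin-4-yl would do the same alongside a different large group on the other side of the ring.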